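Cyclohexyl to isopropyl on the ring nitrogen of compound 1

A few compounds are considered here, and "the series" means these few. Any claim that something is new, unique, unknown or untested is made for them only; others in the source may bear on it.

Of the compounds shown here, three have been measured in a functional assay on cells (Oocyte) for inhibition of Voltage-dependent T-type calcium channel subunit alpha-1H (Homo sapiens), tested at 100 uM; a higher number here means more inhibition at the concentration tested (going by the name of the read-out), a lower number less inhibition. Compound 1 `COC(=O)CC1c2ccccc2N=C(N2CCCCC2)N1C1CCCCC1` gives 27%, compound 2 `COC(=O)CC1c2ccccc2N=C(N2CCOCC2)N1C1CCCCC1` gives 12.2% and compound 3 `COC(=O)CC1c2ccccc2N=C(N2CCN(C)CC2)N1C1CCCCC1` gives 3%. Compound 1 stands highest of the three: the step of a number 14.8 percentage points lower from compound 1 to compound 2 (beyond the scatter) and the step of a number 24 percentage points lower from compound 1 to compound 3 (beyond the scatter) both lie beyond the scatter, while the step of a number 9.2 percentage points lower from compound 2 to compound 3 (within the scatter) lies within it, so compounds 2 and 3 are not ordered against each other.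

All three measured steps vary the group on a carbon with a double bond to nitrogen. The unmeasured compound 4 `COC(=O)CC1c2ccccc2N=C(N2CCCCC2)N1C(C)C` differs from compound 1 elsewhere: isopropyl in place of cyclohexyl on an amine nitrogen in a ring. Among the measured compounds shown here, no measured step touches this position, so none of them bears directly on the change, and the data give no direction for it. In the absence of a relevant precedent the expected step in this assay is taken as small, with wide uncertainty either way. Compound 4 is therefore expected to give 22%, with a range from 5% to 40%. This estimate corresponds to an expected step of a number 5 percentage points lower from compound 1 to compound 4 (within the scatter), which may well remain within the scatter.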

Compound 4, a percentage reported as inhibition, at one concentration (the size of the read-out at that concentration, not a potency): 8%
The estimate for compound 4 lay 14 percentage points above the measured number; the range from low to high includes it.
By their numbers in this assay, from the lowest: compounds 3, 4 and 2 (each within the scatter of the next); then compound 1.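

In this assay, the first change shown on the amine nitrogen in a ring gives the step of a number 19 percentage points lower from compound 1 to compound 4 (beyond the scatter), so this position is not indifferent to the group it carries, and the replacement of cyclohexyl by isopropyl costs inhibition at the concentration tested. The number therefore depends on the group on this nitrogen as well as on the group on the carbon with a double bond to nitrogen, and compound 1, with cyclohexyl and piperidin-1-yl together, stays highest among the four compounds. No supporting measurement bears on why this change has this effect.

Among the compounds shown, this nitrogen carries only cyclohexyl and isopropyl, so it remains open whether the ring itself or the number of carbons matters; cyclopentyl, a longer chain such as n-hexyl, or a benzyl group could separate the two. Also open, as far as these compounds go, is whether a group larger than cyclohexyl on this nitrogen, such as cycloheptyl, would raise the number above that of compound 1, and whether isopropyl has the same effect alongside morpholin-4-yl.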